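Methoxy to anilino on the side chain: notes on compound 4

A few compounds are considered here, and "the series" means these few. Any claim that something is new, unique, unknown or untested is made for them only; others in the source may bear on it.

compound 1 `Cc1c(C)c2c(c(C)c1N)CC(C)(C)O2`: 760 nM
compound 2 `Cc1c(C)c2c(c(C)c1N)CC(C)(CSc1ccncc1)O2`: 630 nM
compound 3 `COCC1(C)Cc2c(C)c(N)c(C)c(C)c2O1`: 300 nM

All three values come from a functional assay (microsomes, liver) with Rattus norvegicus as the target; a lower number here means a stronger inhibitor, a higher number a weaker inhibitor. Compound 3 has the lowest number of the set, and its distance from the other two is modest but beyond the scatter: a 2.1-fold lower number from compound 2 to compound 3 (0.32 log units; beyond the scatter), and a 2.5-fold lower number from compound 1 to compound 3 (0.40 log units; beyond the scatter).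

The next structure is compound 4 `Cc1c(C)c2c(c(C)c1N)CC(C)(CNc1ccccc1)O2`, with anilino in place of methoxy on a saturated chain carbon bound to a saturated ring carbon.

Among the measured compounds shown here, all the measured steps were made at this same place. Of the measured groups there, (pyridin-4-yl)sulfanyl is the closest to anilino in size, and it gave no change beyond the scatter: a 1.2-fold lower number from compound 1 to compound 2 (0.08 log units; within the scatter). Methoxy gave the only gain over hydrogen: a 2.5-fold lower number from compound 1 to compound 3 (0.40 log units; beyond the scatter). Leaving methoxy for the larger group therefore resembles a 2.1-fold lower number from compound 2 to compound 3 (0.32 log units; beyond the scatter) run in reverse, which points to a small rise in the number. For the measured compounds named here, no anilino compound has been measured, so this guide is rough and the range stays wide. The expected step is a 1.5-fold higher number from compound 3 to compound 4 (0.18 log units; within the scatter). For compound 4 the estimated value in this assay is 450 nM, with an expected range of 150 nM to 1100 nM.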

Compound 4, half-maximal inhibitory concentration: 260 nM
Estimate against measurement, compound 4: 1.7-fold (0.24 log units) above; low and high end bracket the measured number.
By their numbers in this assay, from the lowest: compounds 4 and 3 (each within the scatter of the next); then compounds 2 and 1 (each within the scatter of the next).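

At this place, on a saturated chain carbon bound to a saturated ring carbon, the gain over hydrogen in this assay is not confined to the small methoxy group: the anilino group, with 7 heavy atoms and an aromatic ring, also gives one, a 2.9-fold lower number from compound 1 to compound 4 (0.47 log units; beyond the scatter), and it cannot be told apart from methoxy, a 1.2-fold lower number from compound 3 to compound 4 (0.06 log units; within the scatter). The two groups that carry a six-membered aromatic ring do not behave alike, a 2.4-fold lower number from compound 2 to compound 4 (0.38 log units; beyond the scatter), so the presence of a ring and overall group size do not set the number here, with (pyridin-4-yl)sulfanyl standing against any simple size trend. No measurement in hand explains the difference between these groups.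

Going by these compounds, the anilino and (pyridin-4-yl)sulfanyl groups differ in both the atom linking the ring to the chain and the ring itself, so the source of their difference remains open; phenylsulfanyl or (pyridin-4-yl)amino would separate the two. Also open, on these data alone, is whether the hydrogen on the anilino nitrogen matters, a question that N-methylanilino or phenoxy would address.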